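This account rests on a few compounds, and the source may have more. Where it says the series, first, only, none or still open, it means among the compounds named here.

Measured so far:
Compound 1 `CCOc1ccc(NC2=CC(=O)c3c(nc4n3[C@H]3OC[C@@H](O)[C@H]3OC4)C2=O)cc1`. In a functional assay on MCF7 cells (Homo sapiens) for inhibition, read by sulforhodamine B assay (a lower number here means a stronger inhibitor, a higher number a weaker inhibitor), compound 1 gives > 4000 nM, which is a limit of the assay and not a number.
Compound 2 `COc1ccccc1NC1=CC(=O)c2c(nc3n2[C@H]2OC[C@@H](O)[C@H]2OC3)C1=O`. In this assay compound 2 gives 6580 nM.
Compound 3 `O=C1C(NC2CCCCC2)=CC(=O)c2c1nc1n2[C@H]2OC[C@@H](O)[C@H]2OC1`. In this assay compound 3 gives > 16000 nM, again a limit and not a number.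

Compound 3 therefore stands at the weak end of what has been measured: of the three values, it is the one that sits at the limit of > 16000 nM in this assay, at which 1 of the 3 values shown sits, so only a floor for its number is known. Compound 4 `O=C1C(NCc2ccccc2)=CC(=O)c2c1nc1n2[C@H]2OC[C@@H](O)[C@H]2OC1` differs from compound 3 in one place: benzyl in place of cyclohexyl on an amine nitrogen.

Among the compounds with values here, no measured step swaps a cyclohexyl for a benzyl, so the expectation rests on neighbours. The step of an at least 2.4-fold higher number from compound 2 to compound 3 (0.38 log units; beyond the scatter) shows that moving from an aromatic substituent on the amine nitrogen to cyclohexyl made the inhibitor weaker by at least a modest amount. The steps a step that the limit leaves unreadable from compound 1 to compound 2 and a step that the two limits leave unreadable from compound 1 to compound 3 cannot be sized. Returning to a group with one six-membered aromatic ring of carbon only, but through an extra carbon, might recover part of that loss; the expected step is an at least 1.7-fold lower number from compound 3 to compound 4 (0.24 log units; that floor lies within the scatter), a lower number for compound 4, though the limit on compound 3 leaves the size uncertain. Compound 4 is estimated to give 9000 nM in this assay, within 2500 nM to 30000 nM.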

Compound 4, half-maximal inhibitory concentration: > 8000 nM
Compound 4 ended at the assay's limit; the forecaster's own chance of this, stated with the estimate: 45%; the middle value does not contradict the limit.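

In this assay, benzyl in place of cyclohexyl brings a six-membered aromatic ring back onto this amine nitrogen, yet compound 4 still yields a limit of the assay and not a number: the limit of > 8000 nM in this assay, at which 1 of the 4 values shown sits.

Within the data shown here, the only step that can be sized is an at least 1.2-fold higher number from compound 2 to compound 4 (0.08 log units; that floor lies within the scatter), so compound 4 cannot be firmly placed as weaker than compound 2. The steps from compound 3 to compound 4 and from compound 1 to compound 4 cannot be read, which leaves the comparison of benzyl with cyclohexyl unresolved, and among the four compounds only the 2-methoxyphenyl group of compound 2 now gives a measured number.

The compounds shown leave open whether a plain phenyl on the same nitrogen, or a longer chain such as phenylethyl, would give a measured number in this assay. They also leave open whether a methoxy group on the ring of benzyl would do so, a change that would test the same substituent on a different carbon framework.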